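This account rests on a few compounds, and the source may have more. Where it says the series, first, only, none or still open, it means among the compounds named here.

Compound 1 `Cc1ccccc1C(=O)NCc1ccc(CNS(=O)(=O)c2ccc(F)cc2)cc1` sits at 10 nM in an assay on MDA-MB-231 cells for displacement of a labelled ligand from C-X-C chemokine receptor type 4 (Homo sapiens), read by fluorescence and microscopy, with stated times of 10 min and 30 min (a lower number here means that less compound is needed, a higher number that more compound is needed for the effect), the highest of the two numbers given here. Compound 3 `COc1ccccc1C(=O)NCc1ccc(CNS(=O)(=O)c2ccccc2F)cc1` is nearest, with 1 nM in this assay, though it differs from compound 1 in more than one place. Compound 2 `COc1ccccc1C(=O)NCc1ccc(CNS(=O)(=O)c2cccc3ccccc23)cc1` reaches only a limit of the assay, > 1000 nM in this assay. Compound 4 `Cc1ccccc1C(=O)NCc1ccc(CNS(=O)(=O)c2ccccc2Cl)cc1` is not yet measured; it differs from compound 1 by 2-chlorophenyl in place of 4-fluorophenyl on a sulfonyl sulfur. Among the compounds with values here, the one measured step at the sulfonyl sulfur, an at least 1000-fold lower number from compound 2 to compound 3 (3.00 log units; beyond the scatter), shows a 2-fluorophenyl there giving a far lower number than a naphthalen-1-yl, so a 2-chlorophenyl is expected to be tolerated at least as well as the 4-fluorophenyl of compound 1. Compound 4 is therefore estimated at 5 nM (range 1 nM to 30 nM), an expected step of a 2.0-fold lower number from compound 1 to compound 4 (0.30 log units; within the scatter).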

Compound 4, effective concentration (reported as EC, without a stated level of effect): 1000 nM
Beside the measured number, compound 4's estimate is 200-fold (2.30 log units) below it; measured number above the stated range.
By their numbers in this assay, from the lowest: compound 3; then compound 1; then compound 4.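

At the sulfonyl sulfur, exchanging one halogen-carrying phenyl ring for another is not a minor change: a 100-fold higher number from compound 1 to compound 4 (2.00 log units; beyond the scatter) in this assay. The two groups have the same count of heavy atoms and one aromatic ring each, so a large step here needs no change in those counts. The number for compound 4 is a measured value, and it stands at the figure of the limit reached by compound 2: the limit of > 1000 nM in this assay, at which 1 of the 4 values shown sits.

The step from 4-fluorophenyl to 2-chlorophenyl changes both the halogen and its place on the ring. From the compounds shown here alone, whether either alone carries the step remains open, and a 4-chlorophenyl on the core of compound 1 would separate the two.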